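Replacing 4-hydroxyphenyl with 1,3-thiazol-2-yl

A few compounds are considered here, and "the series" means these few. Any claim that something is new, unique, unknown or untested is made for them only; others in the source may bear on it.

Measured in a functional assay on HL-60 cells (Homo sapiens) for inhibition; on this read-out higher numbers stand for weaker inhibition and lower numbers for stronger inhibition:
- compound 1 `OC[C@H]1OC(n2cnc3c(-c4ccco4)ncnc32)[C@H](O)[C@@H]1O`: 2700 nM
- compound 2 `OC[C@H]1OC(n2cnc3c(-c4ccc(O)cc4)ncnc32)[C@H](O)[C@@H]1O`: 7600 nM

Compound 2 holds the higher of the two numbers, the weaker inhibition. Compound 3 `OC[C@H]1OC(n2cnc3c(-c4nccs4)ncnc32)[C@H](O)[C@@H]1O` is not yet measured and differs from compound 2 by 1,3-thiazol-2-yl in place of 4-hydroxyphenyl on an aromatic carbon. Among the measured compounds shown here, the one measured step that bears on this is a 2.8-fold higher number from compound 1 to compound 2 (0.45 log units; beyond the scatter), a modest one that brought in the same 4-hydroxyphenyl. Removing that group in favour of another five-membered aromatic ring is therefore expected to give a modest move to a lower number in this assay. The expected change is a 2.4-fold lower number from compound 2 to compound 3 (0.38 log units; beyond the scatter). For compound 3 the estimated value is 3200 nM, with an expected range of 1000 nM to 9000 nM.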

Compound 3, half-maximal inhibitory concentration: 6300 nM
Estimate against measurement, compound 3: 2.0-fold (0.29 log units) below; measured number inside the range.
By their numbers in this assay, from the lowest: compound 1; then compounds 3 and 2 (each within the scatter of the next).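

In this assay, 1,3-thiazol-2-yl on this aromatic carbon gives a 1.2-fold lower number from compound 2 to compound 3 (0.08 log units; within the scatter), so a five-membered aromatic ring in place of 4-hydroxyphenyl does not by itself reproduce the number of compound 1. The two five-membered rings also differ, with a 2.3-fold higher number from compound 1 to compound 3 (0.37 log units; beyond the scatter), so ring size alone does not set the value among these compounds. Nothing available explains the gap between furan-2-yl and 1,3-thiazol-2-yl.

The compounds shown leave open whether plain phenyl differs from 4-hydroxyphenyl here. From the compounds shown here alone, how an amine or a carboxylic acid at this carbon would read also remains open.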